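The source may report more compounds than this note shows. Statements on the series, on what has been measured and on what is new or still open speak of the compounds shown alone.

Compound 3, `COc1cc2nc([S+]([O-])CC(=O)Nc3ccccc3C(F)(F)F)nc(Nc3c(Cl)cc(/C=C/C#N)cc3Cl)c2cc1OC`, carries a sulfoxide-bearing side chain ending in an amide whose nitrogen bears a 2-(trifluoromethyl)phenyl group. In an ADME assay on MT4 cells (Homo sapiens) for cytotoxicity, read by MTT assay, with a stated time of 5 days (a lower number here means that less compound is tolerated, a higher number that more compound is tolerated), compound 3 gives only a limit, > 192000 nM, as noted in the limit of > 192000 nM in this assay, at which 1 of the 3 values shown sits. Its closest measured neighbour is compound 2, `COc1cc2nc([S+]([O-])CC(=O)Nc3cccc(F)c3)nc(Nc3c(Cl)cc(/C=C/C#N)cc3Cl)c2cc1OC`, which differs only in bearing 3-fluorophenyl on that nitrogen; in this assay compound 2 gives 9550 nM. The step of an at least 20-fold higher number from compound 2 to compound 3 (1.30 log units; beyond the scatter) is therefore large. Compound 1, `COc1cc2nc(SCC(=O)Nc3ccc(Cl)cc3)nc(Nc3c(Cl)cc(/C=C/C#N)cc3Cl)c2cc1OC`, keeps a sulfide in place of the sulfoxide and a 4-chlorophenyl on the amide nitrogen; in this assay compound 1 gives 29500 nM.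

Compound 4, `COc1cc2nc([S+]([O-])CC(=O)Nc3ccc(C)cc3)nc(Nc3c(Cl)cc(/C=C/C#N)cc3Cl)c2cc1OC`, is reached from compound 3 by the change (4-methylphenyl in place of 2-(trifluoromethyl)phenyl on an amide-type nitrogen). Within the data shown here, the one measured step on this nitrogen, an at least 20-fold higher number from compound 2 to compound 3 (1.30 log units; beyond the scatter), shows that swapping the aryl group can move the number a long way, and both compound 1 and compound 2 sit well within the measurable range. A sizable fall from compound 3's limit is therefore expected for compound 4, giving an estimated value of 40000 nM (range 10000 nM to 160000 nM), which corresponds to an expected step of an at least 4.8-fold lower number from compound 3 to compound 4 (0.68 log units; beyond the scatter).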

Compound 4, half-maximal cytotoxic concentration: 32200 nM
Compound 4: the middle estimate sits 1.2-fold (0.09 log units) above what was measured; low and high end bracket the measured number.
By their numbers in this assay, from the lowest: compound 2; then compounds 1 and 4 (each within the scatter of the next). At a limit, above all of these: compound 3.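

Placing 4-methylphenyl on the amide-type nitrogen gives an at least 5.9-fold lower number from compound 3 to compound 4 (0.77 log units; beyond the scatter), so the very high number of compound 3 does not extend to every aryl group at this position. Set against the 3-fluorophenyl amide, the same group gives a 3.4-fold higher number from compound 2 to compound 4 (0.53 log units; beyond the scatter), so in this assay even this smaller swap between aryl groups moves the number beyond the scatter. For compound 3 the value is a limit, so the first of these steps gives only a minimum size: the limit of > 192000 nM in this assay, at which 1 of the 4 values shown sits.

Still open, on these data alone, is whether the high number of compound 3 follows the trifluoromethyl group or its place on the ring, a question that 2-methylphenyl and 4-(trifluoromethyl)phenyl amides could separate. As far as these compounds go, how an amine or a carboxylic acid would read in place of the aryl group also remains open.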